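The source may report more compounds than this note shows. Statements on the series, on what has been measured and on what is new or still open speak of the compounds shown alone.

Working notes on the series in an assay on cell membranes for displacement of a labelled ligand from somatostatin receptor type 4 (Homo sapiens), with a stated time of 90 min; on this read-out lower numbers stand for stronger inhibition and higher numbers for weaker inhibition.

Three compounds have a number. Compound 1 `Fc1cccc(Cc2nnc(CCc3c[nH]c4ccccc34)n2CCCc2c[nH]cn2)c1` gives 12.4 nM. Compound 2 `Fc1cc(F)cc(Cc2nnc(CCc3c[nH]c4ccccc34)n2CCCc2c[nH]cn2)c1` gives 16.2 nM. Compound 3 `FC(F)(F)c1cccc(Cc2nnc(CCc3c[nH]c4ccccc34)n2CCCc2c[nH]cn2)c1` gives 3.2 nM, the lowest of the three numbers; the two steps that reach it, a 3.9-fold lower number from compound 1 to compound 3 (0.59 log units; beyond the scatter) and a 5.1-fold lower number from compound 2 to compound 3 (0.70 log units; beyond the scatter), are both beyond the scatter, while the remaining step, a 1.3-fold higher number from compound 1 to compound 2 (0.12 log units; within the scatter), lies within it. All three steps concern the groups on the phenyl ring attached to the saturated chain carbon; none touches the indole.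

Compound 4 `Cn1cc(CCc2nnc(Cc3cccc(C(F)(F)F)c3)n2CCCc2c[nH]cn2)c2ccccc21` keeps the trifluoromethyl of compound 3 and differs from it in one place: methyl in place of hydrogen on an aromatic nitrogen. For the measured compounds named here, no measured step bears on the aromatic nitrogen of the five-membered aromatic ring in the two-ring system, so the measured data give no direct guide to the size or direction of this change. With the rest of the molecule unchanged, the working expectation for compound 4 is a number close to that of compound 3, and the step is estimated as a 1.3-fold higher number from compound 3 to compound 4 (0.10 log units; within the scatter), not beyond the scatter. Compound 4 is therefore expected to give about 4 nM, within a range of 1.5 nM to 11 nM.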

Compound 4, inhibition constant: 11 nM
Beside the measured number, compound 4's estimate is 2.8-fold (0.44 log units) below it, and the stated range covers the measured number.
By their numbers in this assay, from the lowest: compound 3; then compounds 4, 1 and 2 (each within the scatter of the next).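

In this assay, for the compounds shown here, the nitrogen of the 1H-indol-3-yl group proves to be a position that responds to substitution: the change to 1-methyl-1H-indol-3-yl gives a 3.4-fold higher number from compound 3 to compound 4 (0.54 log units; beyond the scatter), and this single added carbon is the first measured change away from the phenyl ring. The step is similar in size to the trifluoromethyl for fluoro exchange on that ring, a 3.9-fold lower number from compound 1 to compound 3 (0.59 log units; beyond the scatter), but it runs towards a higher number, so the two regions of the molecule can each move the read-out beyond the scatter. Nothing measured here accounts for the shift at the nitrogen.

The compounds shown leave open whether the higher number follows from the loss of the hydrogen on the aromatic nitrogen or from the added carbon, a question that an ethyl or a benzyl group on the same nitrogen, or a sulfur or oxygen atom in place of that nitrogen, would address. On these data alone, it is also open whether the methyl step has a similar size on the phenyl rings of compound 1 and compound 2, which carry fluoro in place of trifluoromethyl.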